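The source may report more compounds than this note shows. Statements on the series, on what has been measured and on what is new or still open speak of the compounds shown alone.

In a functional assay on MOLT-4 cells (Homo sapiens) for inhibition, read by MTT assay, with a stated time of 4 days (on this read-out higher numbers stand for weaker inhibition and lower numbers for stronger inhibition), three compounds sharing one core have been measured. Compound 1 (`COc1cc(NC(C)CCCNC(=O)NNC(=O)Nc2ccc(Cl)c(C(F)(F)F)c2)c2ncccc2c1`), which carries a 4-chloro-3-(trifluoromethyl)phenyl group, gives 19000 nM. Compound 2 (`COc1cc(NC(C)CCCNC(=O)NNC(=O)NCCO)c2ncccc2c1`) reads > 250000 nM, which is a limit of the assay and not a number. Compound 3 (`COc1cc(NC(C)CCCNC(=O)NNC(=O)NCCCC(C)Nc2cc(OC)cc3cccnc23)c2ncccc2c1`) reads >= 250000 nM, and this too is a limit. Compound 2 therefore has no exact position on the scale.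

Compound 4 (`COc1cc(NC(C)CCCNC(=O)NNC(=O)NCCCO)c2ncccc2c1`) differs from compound 2 by hydroxymethyl in place of hydroxy on a saturated chain carbon, two bonds along the chain from an amide-type nitrogen. This places hydroxymethyl in place of hydroxy on a saturated chain carbon, two bonds along the chain from an amide-type nitrogen, so that 2-hydroxyethyl becomes 3-hydroxypropyl.

Among the measured compounds shown here, only one measured step bears on this change: an at least 13-fold higher number from compound 1 to compound 2 (1.11 log units; beyond the scatter). That step is large and beyond the scatter, but it puts 2-hydroxyethyl in place of 4-chloro-3-(trifluoromethyl)phenyl on an amide-type nitrogen. For the measured compounds named here, no measured step lengthens a hydroxy-bearing chain, so it offers only loose guidance. The expectation rests mainly on compound 2, whose reading of > 250000 nM is a limit. The estimated step is a number no higher from compound 2 to compound 4 (the limit leaves the size open), with no change beyond the scatter expected in this assay. A report of compound 4 as a limit is also expected to be likely. For compound 4 the estimate is 250000 nM, with an expected range from 100000 nM to 500000 nM.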

Compound 4, half-maximal inhibitory concentration: > 250000 nM
Compound 4: only a limit was reported (the forecaster's own chance of this, stated with the estimate: 75%); the middle value sits exactly at the limit.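

In this assay compound 4 gives > 250000 nM, which is a limit of the assay, so the longer 3-hydroxypropyl chain brings no reading into the measurable range. The effect of going from 2-hydroxyethyl to 3-hydroxypropyl cannot be read, because compound 2 and compound 4 both rest on the same limit: the limit of > 250000 nM in this assay, at which 2 of the 4 values shown sit. What the new compound does add is a second comparison with the 4-chloro-3-(trifluoromethyl)phenyl group, since putting 3-hydroxypropyl in its place on the amide-type nitrogen gives an at least 13-fold higher number from compound 1 to compound 4 (1.11 log units; beyond the scatter), so the large loss seen with the shorter chain recurs with this one.

The compounds shown leave open how far apart the two hydroxy-bearing chains truly lie, and whether either has any inhibition that could be given as a number in this assay. They also leave open whether a longer chain, a terminal amine or carboxylic acid in place of the hydroxy, or an unsubstituted phenyl ring on this nitrogen would give a value that can be read, and so show how much of compound 1's reading depends on its chloro and trifluoromethyl groups.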